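This account rests on a few compounds, and the source may have more. Where it says the series, first, only, none or still open, it means among the compounds named here.

Working notes on the series.

Three compounds of this set have numbers in an assay on isolated protein for inhibition of DNA topoisomerase 1 (Homo sapiens), tested at 100 uM; on this read-out lower numbers stand for a weaker effect and higher numbers for a stronger effect at the one concentration tested. Compound 1 `Clc1ccc(-c2cc(-c3ccc(Cl)o3)cc(-c3ccsc3)n2)cc1` gives 29.8% in this assay. Compound 2 `Cc1ccc(-c2cc(-c3ccoc3)cc(-c3ccsc3)n2)cc1` gives 13.2% in this assay. Compound 3 `Clc1ccc(-c2cc(-c3ccoc3)cc(-c3cccs3)n2)cc1` gives 0% in this assay, the lowest of the three numbers; its nearest neighbour is compound 2, which stands higher by more than the scatter, and compound 1 stands higher still, also beyond the scatter. No pair among these three differs in one place only, so none of these gaps is a step that can be read on its own.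

Compound 4 `Clc1ccc(-c2cc(-c3ccoc3)cc(-c3ccsc3)n2)cc1` has not yet been measured in this assay. It has the same atoms as compound 3, joined differently: thiophen-3-yl in place of thiophen-2-yl on an aromatic carbon. Within the data shown here, the thiophen-3-yl that enters is the one carried by both compound 1 and compound 2, the two compounds that stand above compound 3 in this assay, whereas compound 3 alone carries thiophen-2-yl. On that basis the expected step is a number 15 percentage points higher from compound 3 to compound 4 (beyond the scatter), an upward one of modest size. In this assay compound 4 is thus expected to give about 15%, within a range from 0% to 32%.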

Compound 4, a percentage reported as inhibition, at one concentration (the size of the read-out at that concentration, not a potency): 0%
The estimate for compound 4 lay 15 percentage points above the measured number, within the range that was stated.
By their numbers in this assay, from the lowest: compounds 3 and 4 (each within the scatter of the next); then compound 2; then compound 1.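

In this assay, the change at the position next to the ring nitrogen, thiophen-3-yl in place of thiophen-2-yl, reads as no change at the digits printed from compound 3 to compound 4 (within the scatter), so the point of attachment of the thiophene does not separate this pair, and thiophen-3-yl alone does not go with a higher number. With thiophen-3-yl now held constant, the other two comparisons can be read one change at a time: chloro in place of methyl on an aromatic carbon gives a number 13.2 percentage points lower from compound 2 to compound 4 (beyond the scatter), and furan-3-yl in place of 5-chlorofuran-2-yl on an aromatic carbon gives a number 29.8 percentage points lower from compound 1 to compound 4 (beyond the scatter). No measurement shown here accounts for any of these steps.

The compounds shown leave open whether thiophen-2-yl and thiophen-3-yl would also stand level alongside the 5-chlorofuran-2-yl group or with methyl in place of chloro, as compound 1 and compound 2 carry only thiophen-3-yl. Also open, on these data alone, is how the number would respond to a different kind of group at this position, such as an aminomethyl group or a carboxylic acid in place of the thiophene.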